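Sulfonate ester series: amide nitrogen substituent, ethyl to cyclopentyl

This account rests on a few compounds, and the source may have more. Where it says the series, first, only, none or still open, it means among the compounds named here.

Compound 2 `CCNC(=O)Nc1ccc(S(=O)(=O)Oc2ccccc2C(C)C)cc1` is one of two members of the series with a number in a functional assay on MCF7 cells (Homo sapiens) for antiproliferative activity, read by sulforhodamine B assay, with a stated time of 48 h; a higher number here means a weaker inhibitor, a lower number a stronger inhibitor. In this assay compound 2 gives 10000 nM, the higher of the two numbers, with compound 1 `CC(C)c1ccccc1OS(=O)(=O)c1ccc(NC(=O)CCCl)cc1` nearest at 9000 nM. For the measured compounds named here, the only step between measured compounds, a 1.1-fold higher number from compound 1 to compound 2 (0.05 log units; within the scatter), exchanges the group on the carbonyl carbon and leaves the numbers where they were.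

Compound 3 `CC(C)c1ccccc1OS(=O)(=O)c1ccc(NC(=O)NC2CCCC2)cc1` is not yet measured. It differs from compound 2 by cyclopentyl in place of ethyl on an amide-type nitrogen. Going by the values given here, no measured step touches the substituent on this amide-type nitrogen, so the bearing of the one known step is indirect: it shows only that an exchange at the neighbouring carbonyl carbon, a 1.1-fold higher number from compound 1 to compound 2 (0.05 log units; within the scatter), stayed within the scatter. On that basis no step beyond the scatter is expected in this assay for the ethyl-to-cyclopentyl exchange, in either direction, and the step of no change at the digits printed from compound 2 to compound 3 (within the scatter) is an estimate rather than a trend. Compound 3 is therefore estimated at 10000 nM in this assay, with a range from 4000 nM to 25000 nM.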

Compound 3, half-maximal inhibitory concentration: 6200 nM
Compound 3: middle estimate off by 1.6-fold (0.21 log units), on the high side; measured number inside the range.
By their numbers in this assay, from the lowest: compounds 3, 1 and 2 (each within the scatter of the next).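

The substituent on the amide-type nitrogen now has a measured step of its own: in this assay, cyclopentyl in place of ethyl gives (a 1.6-fold lower number from compound 2 to compound 3 (0.21 log units; within the scatter)), so an open ethyl group and a five-membered carbon ring at this place are not separated beyond the scatter. The exchange on the carbonyl carbon, read again with the new compound, gives (a 1.5-fold lower number from compound 1 to compound 3 (0.16 log units; within the scatter)), so cyclopentylamino stands with 2-chloroethyl within the scatter, as ethylamino did, and the three compounds remain a single group of numbers. Nothing on hand accounts for these numbers.

Still open is whether any group on this nitrogen gives a step beyond the scatter, since only ethyl and cyclopentyl are shown there; a phenyl ring, a longer chain carrying an amine, or one ending in a carboxylic acid would extend the comparison. Also open is whether the shared core, the same in all three compounds, has any bearing on the numbers, as every step shown lies in the group on the carbonyl carbon or on its nitrogen.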